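A few compounds are considered here, and "the series" means these few. Any claim that something is new, unique, unknown or untested is made for them only; others in the source may bear on it.

Compound 1 `CC(O)(CSc1ccc(C(F)(F)F)cc1)C(=O)Nc1cccc(S(F)(F)(F)(F)F)c1` gives 17500 nM 
Compound 2 `CC(O)(CSc1cccc(C(F)(F)F)c1)C(=O)Nc1cccc(S(F)(F)(F)(F)F)c1` gives 12700 nM 

In a functional assay on LNCaP cells (Homo sapiens) for antiproliferative activity, read by propidium iodide staining, with a stated time of 96 h (a lower number here means a stronger inhibitor, a higher number a weaker inhibitor), compound 2 stands at 12700 nM and lies within the scatter of compound 1 at 17500 nM in this short series. Compound 3 `CC(O)(CSc1cc(C(F)(F)F)cc(C(F)(F)F)c1)C(=O)Nc1cccc(S(F)(F)(F)(F)F)c1` differs from compound 2 by trifluoromethyl in place of hydrogen on an aromatic carbon with trifluoromethyl in place of hydrogen on an aromatic carbon. For the measured compounds named here, the one measured step is a 1.4-fold lower number from compound 1 to compound 2 (0.14 log units; within the scatter) and it relocates a trifluoromethyl group without adding one, so it bears only indirectly. Going by the values given here, no measured step adds such a group. In this assay a step of a 1.3-fold lower number from compound 2 to compound 3 (0.10 log units; within the scatter) is expected, with nothing beyond the scatter. Compound 3 is estimated at 10000 nM with an expected range from 4000 nM to 25000 nM in this read-out.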

Compound 3, half-maximal inhibitory concentration: 4800 nM
Beside the measured number, compound 3's estimate is 2.1-fold (0.32 log units) above it; measured number inside the range.
By their numbers in this assay, from the lowest: compound 3; then compounds 2 and 1 (each within the scatter of the next).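

In this assay, adding a second trifluoromethyl to the aromatic ring gives a 2.6-fold lower number from compound 2 to compound 3 (0.42 log units; beyond the scatter), a modest step beyond the scatter. The earlier change, a 1.4-fold lower number from compound 1 to compound 2 (0.14 log units; within the scatter), moved the only trifluoromethyl and stayed within the scatter, so this aromatic carbon tolerates a second trifluoromethyl with a gain in inhibition. No measured evidence bears on the origin of this gain.

Whether the gain is specific to trifluoromethyl remains open, since the compounds shown carry no other group at this carbon. A chlorine, a nitrile or a methoxy group there could separate the effect of this group from that of any substituent.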